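The compounds below may be only part of what the source reports. "The series", "measured", "known", "first", "only" and "open" are said of these compounds alone.

Values so far in a functional assay on HOP-92 cells (Homo sapiens) for inhibition, read by sulforhodamine B assay, with a stated time of 48 h (a lower number here means a stronger inhibitor of growth, a higher number a weaker inhibitor of growth), are these:
Compound 1 `Cc1ccc(NC(=O)/C=C/c2ccccc2)c(C(N)=O)c1` gives 11400 nM
Compound 2 `NC(=O)c1cc(Br)ccc1NC(=O)/C=C/c1ccccc1` gives 1960 nM
Compound 3 `NC(=O)c1cc(I)ccc1NC(=O)/C=C/c1ccccc1` gives 21200 nM

Compound 3 shares the high end of these numbers with compound 1, as the gap between them shows no real difference (a 1.9-fold higher number from compound 1 to compound 3 (0.27 log units; within the scatter)). The other gap is far wider (an 11-fold higher number from compound 2 to compound 3 (1.03 log units; beyond the scatter)).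

The next compound to be measured is compound 4 `NC(=O)c1cc(I)ccc1NC(=O)/C=C/c1ccccc1Cl`. It carries chloro in place of hydrogen on an aromatic carbon, ortho to a large group, so that phenyl becomes 2-chlorophenyl (chloro in place of hydrogen on an aromatic carbon).

Going by the values given here, no measured step adds a chloro to that phenyl, so none bears directly on this change. Among the compounds with values here, all the measured steps swap one group for another elsewhere in the molecule. They show only how far a single swap can move these compounds: a 5.8-fold lower number from compound 1 to compound 2 (0.76 log units; beyond the scatter) is modest, and an 11-fold higher number from compound 2 to compound 3 (1.03 log units; beyond the scatter) is large. They give no direction for the new chloro, so no step beyond the scatter is expected, but the uncertainty stays wide. The estimated step is a 1.4-fold lower number from compound 3 to compound 4 (0.15 log units; within the scatter) in this assay as the working expectation. For compound 4 the expected value is 15000 nM with 4000 nM to 50000 nM as the estimated range.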

Compound 4, concentration for 50% growth inhibition: 13200 nM
Compound 4: middle estimate off by 1.1-fold (0.06 log units), on the high side, within the range that was stated.
By their numbers in this assay, from the lowest: compound 2; then compounds 1, 4 and 3 (each within the scatter of the next).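

In this assay, going by these compounds alone, replacing hydrogen with chloro ortho to a large group, so that phenyl becomes 2-chlorophenyl, gives a 1.6-fold lower number from compound 3 to compound 4 (0.21 log units; within the scatter) and offers the first reading of a change on this phenyl. The earlier steps shown here all swapped methyl, bromo or iodo elsewhere in the molecule, and one of them, an 11-fold higher number from compound 2 to compound 3 (1.03 log units; beyond the scatter), showed that a single swap can move the number well beyond the scatter, whereas adding chloro at this position on the iodo compound gives no measurable shift. Nothing available explains why this position shows no real difference with chloro.

This single pair cannot show whether chloro would also leave the number unchanged on the bromo compound, where compound 2 gives 1960 nM and the background is different. It also leaves open what a methoxy group, an amine or a carboxylic acid would do at this same position, and whether chloro placed elsewhere on the phenyl would behave in the same way.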